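The compounds below may be only part of what the source reports. "The series", "measured", "known", "first", "only" and "open" are said of these compounds alone.

Measured so far:
compound 1 `O=C(Nc1cc2ccccc2s1)c1ccc([N+](=O)[O-])o1` gives 38000 nM
compound 2 `CC(C)(NC(=O)c1ccc([N+](=O)[O-])o1)c1ccc(Cl)cc1` gives 81000 nM

Compound 2 stands higher of the two with 81000 nM in an ADME assay on Vero cells (Chlorocebus sabaeus) for cytotoxicity, read by MTT assay, with a stated time of 48 h (a lower number here means that less compound is tolerated, a higher number that more compound is tolerated), and compound 1 lies lower by a margin beyond the usual scatter of repeated measurements. The next compound to consider is compound 3 `CC(C)(NC(=O)c1ccc([N+](=O)[O-])o1)c1ccc(C#N)cc1` which keeps all of compound 2 except one group. It carries cyano in place of chloro on an aromatic carbon and this change sits para to a large group.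

Within the data shown here, no two measured compounds differ in just one place, so the data give no direct guide to the size of this swap. Structures as different as compound 2 and compound 1 (38000 nM) still lie fairly close together. A swap of one small group is therefore expected to bring no change beyond the scatter in this assay and no clear direction can be given. The estimated move a 1.1-fold higher number from compound 2 to compound 3 (0.05 log units; within the scatter) is accordingly small. For compound 3 the expected value is 90000 nM with 40000 nM to 200000 nM as the estimated range.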

Compound 3, half-maximal cytotoxic concentration: 83000 nM
For compound 3 the middle estimate is 1.1-fold (0.04 log units) above the measured one; low and high end bracket the measured number.
By their numbers in this assay, from the lowest: compound 1; then compounds 2 and 3 (each within the scatter of the next).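

Among these compounds, this is the first pair of compounds that differ in only one place, so the size of a single swap can now be read directly: in this assay, the step is a 1.0-fold higher number from compound 2 to compound 3 (0.01 log units; within the scatter). At this position on the aromatic ring, para to a large group, cyano with its two heavy atoms and one hydrogen-bond acceptor therefore takes the place of chloro, with its one heavy atom and no acceptor, without a difference that this assay can separate from ordinary repeat variation. No measurement at hand bears on why the two compounds match so closely, and a single pair cannot settle that question.

This one swap does not show whether any group at this position would give the same result, and an amine or a carboxylic acid in the same place could behave quite differently. It also leaves open whether a change of similar size elsewhere on the shared core would have as little effect on the number in this assay.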